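The source may report more compounds than this note shows. Statements on the series, on what has been measured and on what is new or still open speak of the compounds shown alone.

Compound 1, `Cc1ccc(C(=O)N2N=C(c3cc4ccccc4oc3=O)CC2c2ccccc2)cc1`, gives 13200 nM in a functional assay on PC-3 cells (Homo sapiens) for cytotoxicity, read by MTT assay, with a stated time of 48 h; a higher number here means a weaker inhibitor, a lower number a stronger inhibitor.
Compound 2, `Cc1ccc(S(=O)(=O)N2N=C(c3cc4ccccc4oc3=O)CC2c2ccccc2)cc1`, gives 48600 nM in this assay.
Compound 3, `CC(C)(C)NCC(=O)N1N=C(c2cc3ccccc3oc2=O)CC1c1ccccc1`, gives 16400 nM in this assay.

All three share the same core and differ only in the group attached to the amine nitrogen in the ring. Compound 3 holds the second highest of the three numbers: its nearest neighbour is reached by a 1.2-fold higher number from compound 1 to compound 3 (0.09 log units; within the scatter), its furthest by a 3.0-fold lower number from compound 2 to compound 3 (0.47 log units; beyond the scatter). Compound 4, `NC(=O)C1CCN(CC(=O)N2N=C(c3cc4ccccc4oc3=O)CC2c2ccccc2)CC1`, has not yet been measured. It differs from compound 3 in one place: 4-carbamoylpiperidin-1-yl in place of (tert-butyl)amino on a saturated chain carbon bound to a carbonyl carbon. Among the compounds with values here, none of the measured steps touches this part of the molecule. Within the data shown here, the closest precedent is the exchange of the whole group on the carbonyl carbon, which gave a 1.2-fold higher number from compound 1 to compound 3 (0.09 log units; within the scatter); the only larger shift, a 3.7-fold higher number from compound 1 to compound 2 (0.57 log units; beyond the scatter), came from replacing the carbonyl itself with a sulfonyl, and compound 4 keeps the carbonyl. With no direct guide, the expected step in this assay is none beyond the scatter, estimated at a 1.0-fold lower number from compound 3 to compound 4 (0.01 log units; within the scatter). Compound 4 is therefore expected to give about 16000 nM, with a likely range from 6000 nM to 45000 nM.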

Compound 4, half-maximal inhibitory concentration: 8310 nM
For compound 4 the middle estimate is 1.9-fold (0.28 log units) above the measured one; low and high end bracket the measured number.
By their numbers in this assay, from the lowest: compounds 4, 1 and 3 (each within the scatter of the next); then compound 2.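

In this assay, this is the first change shown at the saturated chain carbon bound to a carbonyl carbon, and the step, a 2.0-fold lower number from compound 3 to compound 4 (0.30 log units; within the scatter), stays within the usual scatter even though 4-carbamoylpiperidin-1-yl has more heavy atoms than (tert-butyl)amino and brings a six-membered non-aromatic ring. The wider exchange on the carbonyl carbon, (4-carbamoylpiperidin-1-yl)methyl in place of 4-methylphenyl, gives a 1.6-fold lower number from compound 1 to compound 4 (0.20 log units; within the scatter), so the three compounds that keep the carbonyl read alike despite very different groups on it, while compound 2, with its sulfonyl, goes against this pattern at 48600 nM. No accompanying measurement accounts for this result.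

The compounds shown leave open how much the carbamoyl itself contributes, as a plain piperidine or a piperidine bearing a carboxylic acid in its place would be needed to separate it from the ring. They also leave open whether a longer chain carrying the same 4-carbamoylpiperidin-1-yl would still read alike in this assay.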